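The compounds below may be only part of what the source reports. "The series", "measured", "known", "first", "only" and "open" are said of these compounds alone.

Measured in a functional assay on A2780 cells (Homo sapiens) for cytotoxicity, read by MTT assay, with a stated time of 24 h; a lower number here means a stronger inhibitor, a higher number a weaker inhibitor:
- compound 1 `CCCCC[C@H](C[C@@H](O)C[C@H]1CC=CC(=O)O1)OC`: 28900 nM
- compound 2 `CCCCC[C@@H](CCC[C@@H]1CC=CC(=O)O1)OC`: 14900 nM

Among the measured compounds shown here, compound 2 has only one neighbour on these numbers, compound 1, and the two values lie within the scatter of each other, so neither can be ranked above the other. For the measured compounds named here, both are the only readings available for the series in this assay.

Next is compound 3 `CCCCC[C@H](CCC[C@H]1CC=CC(=O)O1)OC`, still unmeasured. The change is the two compounds have the same atoms and bonds and differ only in configuration as drawn: 2 of 2 stereo elements differ (all stereocentres are inverted: mirror images); a stereocentre at a saturated chain carbon is drawn S in compound 2 and R in compound 3; a stereocentre at a saturated ring carbon is drawn R in compound 2 and S in compound 3. Compound 3 has the same atoms and bonds as compound 2, and all stereocentres are inverted, which makes the two mirror images: a stereocentre at a saturated chain carbon is drawn S in compound 2 and R in compound 3, and a stereocentre at a saturated ring carbon is drawn R in compound 2 and S in compound 3.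

Going by the values given here, the data hold no measured pair of mirror images, so no step shows how much this inversion matters here. With no evidence for a direction, no change beyond the scatter is expected, and the expected move is a 1.2-fold higher number from compound 2 to compound 3 (0.08 log units; within the scatter). For compound 3 the estimated value is 18000 nM, with an expected range of 7000 nM to 45000 nM.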

Compound 3, half-maximal inhibitory concentration: 17100 nM
For compound 3 the middle estimate is 1.1-fold (0.02 log units) above the measured one; the measured number falls inside the stated range.
By their numbers in this assay, from the lowest: compounds 2, 3 and 1 (each within the scatter of the next).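

This mirror-image pair gives a 1.1-fold higher number from compound 2 to compound 3 (0.06 log units; within the scatter) in this assay, so inverting both stereocentres together leaves the two readings indistinguishable, and the comparison is clean on one point: the fact that compounds 2 and 3 differ only in the configuration as drawn

The series also now has its first step at the hydroxy position: hydrogen in place of hydroxy on a saturated chain carbon bound to two saturated chain carbons gives a 1.7-fold lower number from compound 1 to compound 3 (0.23 log units; within the scatter). Neither change therefore separates the compounds in this assay, and within these three compounds no reading can be placed above another on either the configuration or that hydroxy.

As far as these compounds go, both stereocentres move together in the mirror-image pair, so it remains open whether inverting only one of them, at the saturated chain carbon or at the saturated ring carbon, would give a step beyond the scatter. It is also open whether an amine or a carboxylic acid in place of the hydroxy, or a longer chain, would shift the number in this assay, since the two steps shown cover only hydrogen against hydroxy and configuration.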